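This account rests on a few compounds, and the source may have more. Where it says the series, first, only, none or still open, it means among the compounds named here.

Three thiourea-linked analogues of a shared core have been tested, and a fourth is still awaiting its number. Compound 1 `Cc1ccc(NC(=S)NC(=O)c2cn(-c3ccccc3)nc2-c2ccccc2)cc1` gives 2800 nM in a functional assay on A549 cells (Homo sapiens) for inhibition, read by CCK-8 assay, with a stated time of 48 h; on this read-out higher numbers stand for weaker inhibition and lower numbers for stronger inhibition. Compound 3 `O=C(NC(=S)Nc1ccc(Cl)cc1)c1cn(-c2ccccc2)nc1-c1ccccc1` gives 3200 nM in this assay. Compound 2 `O=C(NC(=S)Nc1ccc(F)cc1)c1cn(-c2ccccc2)nc1-c1ccc(Cl)cc1` gives 3980 nM in this assay. Of the three numbers, that of compound 2 is the highest, yet its gaps to compound 3 and to compound 1 both sit within the scatter, so no ordering can be read from them. How the core of compound 2 differs from that of compound 3 is not broken down here.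

The step from compound 3 to compound 1 is methyl in place of chloro on an aromatic carbon, and it gave a 1.1-fold lower number from compound 3 to compound 1 (0.06 log units; within the scatter). Compound 4 `Cc1ccc(-c2nn(-c3ccccc3)cc2C(=O)NC(=S)Nc2ccc(F)cc2)cc1` carries the same change relative to compound 2, namely (methyl in place of chloro on an aromatic carbon); cut one bond further out it reads 4-chlorophenyl to 4-methylphenyl, where the earlier pair also read (4-chlorophenyl)amino to (4-methylphenyl)amino. Because the step from compound 3 to compound 1 was a 1.1-fold lower number from compound 3 to compound 1 (0.06 log units; within the scatter), the step from compound 2 to compound 4 is expected to be similarly small, about a 1.1-fold lower number from compound 2 to compound 4 (0.06 log units; within the scatter). Compound 4 is therefore estimated at 3500 nM, most likely between 1800 nM and 7500 nM.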

Compound 4, half-maximal inhibitory concentration: 3420 nM
Estimate against measurement, compound 4: 1.0-fold (0.01 log units) above; the measured number falls inside the stated range.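

Methyl in place of chloro in the 4-chlorophenyl group of compound 2 gave, in this assay, a 1.2-fold lower number from compound 2 to compound 4 (0.07 log units; within the scatter). Set beside the earlier step, the change reads alike on both cores: the same change on two cores in this assay, a 1.1-fold lower number (0.06 log units; within the scatter) from compound 3 to compound 1 and a 1.2-fold lower number (0.07 log units; within the scatter) from compound 2 to compound 4, 1.0-fold (0.01 log units) apart, within the scatter of two such steps. This shows that on these two cores the exchange stays within the scatter, whether it is made on the (4-chlorophenyl)amino group or on the 4-chlorophenyl group; it does not show that methyl and chloro can be told apart at either place, and two pairs make no rule for the whole series.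

The compounds shown leave open whether a group of another kind on that aromatic carbon, such as an amine, a carboxylic acid or a longer alkyl chain, would give a step beyond the scatter. They also leave open whether the exchange of chloro for methyl would stay this small on a core in which the thiourea link is replaced by a plain amide.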